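The compounds below may be only part of what the source reports. "The series", "measured", "known", "first", "only" and "open" are said of these compounds alone.

Measured so far in a functional assay, read by spectrophotometry, with a stated time of 30 min; on this read-out lower numbers stand for stronger inhibition and higher numbers for weaker inhibition:
Compound 1 `CCOC(=O)[C@H](CC(C)C)NC(=O)/C=C/c1ccc(O)c(OC)c1` gives 56100 nM.
Compound 2 `CCOC(=O)[C@H](C)NC(=O)/C=C/c1ccc(O)c(OC)c1` gives 46400 nM.

Compound 1 has the higher of the two numbers, but the step of a 1.2-fold lower number from compound 1 to compound 2 (0.08 log units; within the scatter) is within the scatter, so the two compounds are not ordered. Compound 3 `CCOC(=O)[C@H](CC(C)C)NC(=O)/C=C/c1ccc(OC(C)=O)c(OC)c1` differs from compound 1 by acetyl in place of hydrogen on an oxygen on an aromatic ring. Among the compounds with values here, the single measured step, a 1.2-fold lower number from compound 1 to compound 2 (0.08 log units; within the scatter), alters a saturated chain carbon and not the oxygen on the aromatic ring, so no measured step bears on this change. In this assay there is no basis for a shift; for compound 3 the expected step is a 1.0-fold lower number from compound 1 to compound 3 (0.00 log units; within the scatter), with wide uncertainty. Compound 3 is therefore estimated at 56000 nM, range 18000 nM to 170000 nM.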

Compound 3, half-maximal inhibitory concentration: > 500000 nM
Compound 3 ended at the assay's limit; the forecaster's own chance of this, stated with the estimate: 20%; middle value at least 8.9-fold (0.95 log units) away from the limit.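

In this assay compound 3 gives > 500000 nM as a limit of the assay and not a number. Hydroxy to acetoxy on the oxygen on the aromatic ring gives the first step in the series beyond the scatter (an at least 8.9-fold higher number from compound 1 to compound 3 (0.95 log units; beyond the scatter)). This oxygen therefore responds to substitution, unlike the saturated chain carbon, whose step stays within the scatter (a 1.2-fold lower number from compound 1 to compound 2 (0.08 log units; within the scatter)).

The compounds shown do not tell whether a methyl ether or a carbamate on this oxygen would give a similar step. On these data alone, whether acetoxy acts the same way on the core of compound 2 also remains open.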